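Swapping fluoro for chloro in a 5-lipoxygenase inhibitor series

The source may hold more compounds than are shown below. What is called first, only, known or untested is meant among the compounds shown, and "the series" means these compounds.

Of the compounds shown here, two sharing one core have been measured in a functional assay on cells for inhibition of Polyunsaturated fatty acid 5-lipoxygenase (Homo sapiens); a lower number here means a stronger inhibitor, a higher number a weaker inhibitor. Compound 1 `O=C1NCCN(c2cccc(Cl)c2)N1` gives 2100 nM in this assay. Compound 2 `CC1CN(c2cccc(F)c2)NC(=O)N1` gives 1800 nM, the lowest of the two numbers, though its nearest neighbour compound 1 sits within the usual scatter, so the two cannot be ranked. Compound 3 `CC1CN(c2cccc(Cl)c2)NC(=O)N1` has not been measured yet. It differs from compound 2 in one place: chloro in place of fluoro on an aromatic carbon. Compound 1 also carries a chloro group and comes out close to compound 2, so the swap offers no sign of a large shift in either direction. The expectation for compound 3 in this assay is therefore a value much like that of compound 2, with the step from compound 2 to compound 3 estimated at a 1.1-fold higher number from compound 2 to compound 3 (0.02 log units; within the scatter), within the scatter. Compound 3 is expected to give about 1900 nM, likely between 900 nM and 4000 nM.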

Compound 3, half-maximal inhibitory concentration: 2700 nM
Estimate against measurement, compound 3: 1.4-fold (0.15 log units) below, and the stated range covers the measured number.
By their numbers in this assay, from the lowest: compounds 2, 1 and 3 (each within the scatter of the next).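

In this assay, chloro in place of fluoro on an aromatic carbon gives a 1.5-fold higher number from compound 2 to compound 3 (0.18 log units; within the scatter) and so shows that, at this position, these two halogens cannot be told apart. The new compound also isolates a second change, methyl in place of hydrogen on a saturated ring carbon, which gives a 1.3-fold higher number from compound 1 to compound 3 (0.11 log units; within the scatter) and likewise leaves no readable difference. No data at hand bear on why either swap leaves the number within the scatter.

On these data alone, it remains open whether a group of a different kind on the aromatic carbon, such as a methoxy group, a nitrile or an amine, would move the number beyond the scatter. The same question stands for a longer chain, such as ethyl or propyl, in place of methyl on the saturated ring carbon.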